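Capping the free hydroxy of compound 2

A few compounds are considered here, and "the series" means these few. Any claim that something is new, unique, unknown or untested is made for them only; others in the source may bear on it.

Going by the values given here, in a functional assay on MDA-MB-231 cells (Homo sapiens) for antiproliferative activity, read by sulforhodamine B assay, with a stated time of 72 h (a lower number here means a stronger inhibitor, a higher number a weaker inhibitor), compound 2 (`COc1ccc(O)c(C(=O)/C=C/c2csc3ccccc23)c1`) gives 760 nM, the lowest number so far, against compound 1 (`Cc1ccc(O)c(C(=O)/C=C/c2csc3ccccc23)c1`) at 6000 nM and compound 3 (`CC(C)Oc1ccc(O)c(C(=O)/C=C/c2csc3ccccc23)c1`) at 8500 nM. Compound 4 (`COc1ccc(OC)c(C(=O)/C=C/c2csc3ccccc23)c1`) has methyl in place of hydrogen on an oxygen on an aromatic ring, turning hydroxy to methoxy: methyl in place of hydrogen on an oxygen on an aromatic ring. Among the compounds with values here, no measured compound changes that hydroxy, so the evidence is indirect. The nearest guides alter a different group, and they were sizeable: a 7.9-fold lower number from compound 1 to compound 2 (0.90 log units; beyond the scatter) and an 11-fold higher number from compound 2 to compound 3 (1.05 log units; beyond the scatter). Both show that a small change can move this number, and each departure from compound 2 raised it. A moderate rise is therefore expected, a 3.3-fold higher number from compound 2 to compound 4 (0.52 log units; beyond the scatter). For compound 4 the estimated value is 2500 nM, within a range of 600 nM to 10000 nM.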

Compound 4, half-maximal inhibitory concentration: 5400 nM
Compound 4: middle estimate off by 2.2-fold (0.33 log units), on the low side; low and high end bracket the measured number.
By their numbers in this assay, from the lowest: compound 2; then compounds 4, 1 and 3 (each within the scatter of the next).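

Going by these compounds alone, this is the first compound in which the hydroxy itself changes. In this assay, methyl in place of hydrogen on an oxygen on an aromatic ring gives a 7.1-fold higher number from compound 2 to compound 4 (0.85 log units; beyond the scatter) and shows that this hydroxy is not a silent spot: a single added methyl here moves the number beyond the scatter. Nothing measured here explains the rise.

The compounds shown leave open how an amine or a fluorine in place of this hydroxy would read. As far as these compounds go, a longer chain on the same oxygen, such as ethyl, also remains open.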